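From a ring amine to its guanidine counterpart

The source may report more compounds than this note shows. Statements on the series, on what has been measured and on what is new or still open speak of the compounds shown alone.

In a physicochemical assay for acid dissociation, using potentiometric titration, compound 1 `COc1cccc(CC2CCCNC2)c1` gives 9.9, and compound 2 `c1cc(CC2CCCNC2)c2ccoc2c1` gives 9.8; the two numbers lie within the scatter of each other, so neither stands apart. Compound 3 `N=C(N)N1CCCC(Cc2cccc3occc23)C1` differs from compound 2 in one place: a group of 3 heavy atoms (1 carbon, 2 nitrogen; no ring) in place of a hydrogen atom, on an amine nitrogen in a ring. Among the measured compounds shown here, no measured pair shows such a change, so its effect on this assay has to be guessed. A large upward step a number 3.00 log units higher from compound 2 to compound 3 (beyond the scatter) from compound 2 to compound 3 is expected. For compound 3 the value is estimated at 12.8, with a range from 12 to 13.6.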

Compound 3, acid dissociation constant: > 11
Compound 3 ended at the assay's limit; the forecaster's own chance of this, stated with the estimate: 15%; the middle value lies beyond the limit too.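

In this assay compound 3 gives > 11, which is a limit of the assay and not a number. Compound 1 and compound 2 both keep a hydrogen atom on the amine nitrogen in a ring, and replacing it with this group moves the reading a number at least 1.20 log units higher from compound 2 to compound 3 (beyond the scatter). The size of that step is therefore bounded on one side only: the limit of > 11 in this assay, at which 1 of the 3 values shown sits.

The compounds shown leave open how far past the limit compound 3 lies. They also leave open what a methyl group or an acetyl group on the same nitrogen would read.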